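A few compounds are considered here, and "the series" means these few. Any claim that something is new, unique, unknown or untested is made for them only; others in the source may bear on it.

In a physicochemical assay for solubility, read by HPLC, in phosphate buffer, with a stated time of 4 h, at pH 7.4, tested at 10 mg/mL (a higher number here means a more soluble compound, a lower number a less soluble compound), compound 2 `Cc1cc(CCC#N)cc(C)c1Oc1cc(Nc2ccc(C#N)cc2)c(N)cc1C(=O)NC1CC1` gives 1.94 ug/mL. Among the compounds with values here, its one measured neighbour, compound 1 `CCNC(=O)c1cc(N)c(Nc2ccc(C#N)cc2)cc1Oc1c(C)cc(CCC#N)cc1C`, gives 1.08 ug/mL in this assay, and the step of a 1.8-fold higher number from compound 1 to compound 2 (0.25 log units; within the scatter) lies within the scatter, so the two stand together rather than apart. Compound 3 `Cc1cc(CCC#N)cc(C)c1Oc1cc(Nc2ccc(C#N)cc2)c(N)cc1CN(C)C` differs from compound 2 by (dimethylamino)methyl in place of cyclopropylcarbamoyl on an aromatic carbon. Within the data shown here, no measured step covers this change; the single step known concerns another place and gives no guide to its size or direction. Compound 3 is therefore expected at 8 ug/mL, with a range from 1.5 ug/mL to 40 ug/mL. The estimated step is a 4.1-fold higher number from compound 2 to compound 3 (0.62 log units; beyond the scatter), upward but held loosely.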

Compound 3, solubility: 23.4 ug/mL
The estimate for compound 3 lay 2.9-fold (0.47 log units) below the measured number, within the range that was stated.
By their numbers in this assay, from the lowest: compounds 1 and 2 (each within the scatter of the next); then compound 3.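

At this aromatic carbon in this assay, (dimethylamino)methyl in place of cyclopropylcarbamoyl gives a large rise (a 12-fold higher number from compound 2 to compound 3 (1.08 log units; beyond the scatter)), and in place of ethylcarbamoyl an equally clear one (a 22-fold higher number from compound 1 to compound 3 (1.34 log units; beyond the scatter)). So exchanging the whole amide here moves the number well beyond the scatter, which the earlier change on the amide nitrogen did not do. Nothing available accounts for this rise. Going by these compounds, it remains open whether a morpholinomethyl or pyrrolidinylmethyl group would give a similar step, and whether a longer chain carrying the dimethylamino group would do so.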